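A few compounds are considered here, and "the series" means these few. Any claim that something is new, unique, unknown or untested is made for them only; others in the source may bear on it.

Measured compounds:
- compound 1, `CN(C(=O)NC(=O)c1ccc(F)c(F)c1)c1nc(C(F)(F)F)c(C(=O)N/N=C/c2ccc(C(F)(F)F)cc2)s1`: 5.1 ug/mL
- compound 2, `CN(C(=O)NC(=O)c1ccc(Cl)cc1Cl)c1nc(C(F)(F)F)c(C(=O)N/N=C/c2ccc(C(F)(F)F)cc2)s1`: 7.99 ug/mL
- compound 3, `CN(C(=O)NC(=O)c1ccc(F)c(F)c1)c1nc(C(F)(F)F)c(C(=O)N/N=C/c2ccccc2C(F)(F)F)s1`: 9.24 ug/mL

All three values come from a functional assay on HeLa cells (Homo sapiens) for inhibition, read by MTT assay, with a stated time of 72 h; on this read-out lower numbers stand for stronger inhibition and higher numbers for weaker inhibition. Compound 2 differs from compound 1 by 2,4-dichlorophenyl in place of 3,4-difluorophenyl on a carbonyl carbon and the result is a 1.6-fold higher number from compound 1 to compound 2 (0.19 log units; within the scatter). Compound 3 differs from compound 1 by 2-(trifluoromethyl)phenyl in place of 4-(trifluoromethyl)phenyl on a carbon with a double bond to nitrogen and the result is a 1.8-fold higher number from compound 1 to compound 3 (0.26 log units; within the scatter). Compound 2 and compound 3 are not linked by a single step here; their two values lie close together.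

Compound 4, `CN(C(=O)NC(=O)c1ccc(Cl)cc1Cl)c1nc(C(F)(F)F)c(C(=O)N/N=C/c2ccccc2C(F)(F)F)s1`, is not yet measured in this assay. It differs from compound 3 by 2,4-dichlorophenyl in place of 3,4-difluorophenyl on a carbonyl carbon, which is the same change already seen from compound 1 to compound 2, made at the same place and with the same surroundings, and so far seen only that once.

The expectation for compound 4 rests on that one earlier step: starting from compound 3 with 9.24 ug/mL, a step of about a 1.6-fold higher number from compound 3 to compound 4 (0.20 log units; within the scatter) is expected, matching a 1.6-fold higher number from compound 1 to compound 2 (0.19 log units; within the scatter) in size. Compound 4 is accordingly estimated at 14.5 ug/mL in this assay, with a range from 7 ug/mL to 30 ug/mL. For the measured compounds named here, the range is wide: only one earlier step, a 1.6-fold higher number from compound 1 to compound 2 (0.19 log units; within the scatter), supports it.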

Compound 4, half-maximal inhibitory concentration: 9 ug/mL
Compound 4: middle estimate off by 1.6-fold (0.21 log units), on the high side; low and high end bracket the measured number.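

In this assay, 2,4-dichlorophenyl in place of 3,4-difluorophenyl on the carbonyl carbon gives a 1.0-fold lower number from compound 3 to compound 4 (0.01 log units; within the scatter), and this sits with the earlier step as follows: the same change on two cores in this assay, a 1.6-fold higher number (0.19 log units; within the scatter) from compound 1 to compound 2 and a 1.0-fold lower number (0.01 log units; within the scatter) from compound 3 to compound 4, 1.6-fold (0.21 log units) apart, within the scatter of two such steps. 2-(trifluoromethyl)phenyl in place of 4-(trifluoromethyl)phenyl gives a 1.1-fold higher number from compound 2 to compound 4 (0.05 log units; within the scatter), and the comparison reads: the same change on two cores in this assay, a 1.8-fold higher number (0.26 log units; within the scatter) from compound 1 to compound 3 and a 1.1-fold higher number (0.05 log units; within the scatter) from compound 2 to compound 4, 1.6-fold (0.21 log units) apart, within the scatter of two such steps. For the compounds shown here, each change therefore carries from one core to the other without a gap beyond the scatter, but all four steps also lie within the scatter, so the series shows only that neither change shifts the number measurably in these two settings, not that either change has a real effect of its own or that the same would hold on another core.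

From the compounds shown here alone, all four compounds carry only halogen or trifluoromethyl on the two phenyl rings, so it remains open whether an amine or a carboxylic acid in those places would give a step beyond the scatter. Also open, going by these compounds, is whether a saturated ring such as cyclohexyl in place of either phenyl ring would do so.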